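Sulfonamide side-chain truncation in the shared core series

The compounds below may be only part of what the source reports. "The series", "measured", "known", "first", "only" and "open" are said of these compounds alone.

Measured so far:
compound 1 `CCC1C(=O)N(C)c2cnc(-n3ccc4cc(C(N)=O)ccc43)nc2N1c1ccn(C)n1` — 27400 nM
compound 2 `CCC1C(=O)N(C)c2cnc(Nc3ccc(S(=O)(=O)NCCCO)cc3)nc2N1c1ccn(C)n1` — 23700 nM
compound 3 `CC[C@@H]1C(=O)N(C)c2cnc(-n3ccc4cc(C(=O)NC)ccc43)nc2N1C1CCCC1` — 768 nM

All three numbers come from a functional assay on HeLa cells (Homo sapiens) for antiproliferative activity, read by CCK-8 assay, with a stated time of 72 h; on this read-out higher numbers stand for weaker inhibition of growth and lower numbers for stronger inhibition of growth. Compound 2 stands alongside compound 1: the two values lie within the scatter of each other, so no order between them can be read. Compound 3 sits far apart from both, its number being lower than that of compound 2 by a gap well beyond the scatter; compound 3 also differs from compound 2 in more than one place, so that gap is not tied to any single change.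

The next compound, compound 4 `CCC1C(=O)N(C)c2cnc(Nc3ccc(S(=O)(=O)NC)cc3)nc2N1c1ccn(C)n1`, differs from compound 2 only at the sulfonamide chain: hydrogen in place of 2-hydroxyethyl on a saturated chain carbon bound to a sulfonamide nitrogen. Among the measured compounds shown here, no step between measured compounds isolates a change of this kind, so no measured reference for its size exists. The change is small and lies at the chain end, away from the core, and the step in this assay from compound 2 to compound 4 is expected to be a 1.1-fold higher number from compound 2 to compound 4 (0.02 log units; within the scatter), not beyond the scatter in either direction. Compound 4 is therefore estimated at 25000 nM, with a range from 9000 nM to 70000 nM.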

Compound 4, concentration for 50% growth inhibition: 2200 nM
The estimate for compound 4 lay 11-fold (1.06 log units) above the measured number; measured number outside the range, below it.
By their numbers in this assay, from the lowest: compound 3; then compound 4; then compounds 2 and 1 (each within the scatter of the next).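

In this assay the sulfonamide chain end proves to be a responsive position on the shared core: replacing (3-hydroxypropyl)sulfamoyl with methylsulfamoyl gives an 11-fold lower number from compound 2 to compound 4 (1.03 log units; beyond the scatter) and therefore stronger inhibition of growth with the methyl group. The earlier compounds shown here offered no step at this position, whereas this pair shows that a change confined to the chain end can move the number beyond the scatter. No measurement at hand bears on why the step has this size.

With only these two chain ends compared, the step cannot yet be assigned to either the hydroxyl or the chain length. An unsubstituted sulfamoyl group, a propyl chain without the hydroxyl, or a chain ending in an amine or a carboxylic acid would test this further.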